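Fluoro for Bromo on the Sulfonyl Aryl Ring

The source may report more compounds than this note shows. Statements on the series, on what has been measured and on what is new or still open speak of the compounds shown alone.

Measured compounds:
compound 1, `COc1cc(Nc2nc3ccccc3nc2S(=O)(=O)c2ccc(C)cc2)cc(OC)c1OC`, 10800 nM
compound 2, `COc1cc(Nc2nc3ccccc3nc2S(=O)(=O)c2ccc(Br)cc2)cc(OC)c1`, a limit of > 50000 nM
compound 3, `COc1cc(Nc2nc3ccccc3nc2S(=O)(=O)c2ccc(Br)cc2)cc(OC)c1OC`, 13000 nM

Three compounds share one core and were tested in a functional assay on HCT-116 cells (Homo sapiens) for cytotoxicity, read by MTT assay, with a stated time of 72 h; a higher number here means a weaker inhibitor, a lower number a stronger inhibitor. Compound 1 gives 10800 nM and compound 3 gives 13000 nM; the step of a 1.2-fold higher number from compound 1 to compound 3 (0.08 log units; within the scatter), so these two cannot be told apart. Compound 2 reaches only a limit of the assay, > 50000 nM, and (the limit of > 50000 nM in this assay, at which 1 of the 3 values shown sits). Against that limit, an at least 3.8-fold lower number from compound 2 to compound 3 (0.58 log units; beyond the scatter). Of the two actual numbers shown, compound 3 has the higher one, with compound 1 nearest and within the scatter.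

Compound 4, `COc1cc(Nc2nc3ccccc3nc2S(=O)(=O)c2ccc(F)cc2)cc(OC)c1OC`, is not yet measured. It differs from compound 3 in one place: fluoro in place of bromo on an aromatic carbon. Among the measured compounds shown here, the only measured step touching the same ring, methyl to bromo, is a 1.2-fold higher number from compound 1 to compound 3 (0.08 log units; within the scatter), which was within the scatter; nothing among the measured compounds separates one halogen from another there. The expectation for this assay is therefore a step of no size beyond the scatter, in no particular direction: a 1.1-fold lower number from compound 3 to compound 4 (0.03 log units; within the scatter) is the estimated change. Compound 4 is expected to give about 12000 nM, with a plausible range from 5000 nM to 30000 nM.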

Compound 4, half-maximal inhibitory concentration: 3110 nM
Compound 4: the middle estimate sits 3.9-fold (0.59 log units) above what was measured, and the stated range ends above it.
By their numbers in this assay, from the lowest: compound 4; then compounds 1 and 3 (each within the scatter of the next). At a limit, above all of these: compound 2.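

The group at this place does matter: the swap of 4-bromophenyl to 4-fluorophenyl gives a 4.2-fold lower number from compound 3 to compound 4 (0.62 log units; beyond the scatter) in this assay and so shows that one halogen cannot simply stand in for another on this ring. Among the compounds shown here, the step of a 3.5-fold lower number from compound 1 to compound 4 (0.54 log units; beyond the scatter) points the same way and sets fluoro apart from methyl as well, a split that could not be seen while the only groups measured here were the methyl of compound 1 and the bromo of compound 3, which could not be told apart. Nothing measured here accounts for why fluoro differs from bromo or methyl at this place.

From the compounds shown here alone, it stays open whether chloro, methoxy or an amine on the same carbon would behave like fluoro or like the two earlier groups. Going by these compounds, it is also open whether fluoro would bring the same gain on the methoxy pattern of compound 2, whose entry of > 50000 nM is a limit of the assay and not a number.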